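Phenyl to Cyclohexyl Made Twice on Two Related Cores

The source may report more compounds than this note shows. Statements on the series, on what has been measured and on what is new or still open speak of the compounds shown alone.

Of the compounds shown here, three have so far been measured in an assay for displacement of a labelled ligand from 5-hydroxytryptamine receptor 4 (Homo sapiens), with a stated time of 60 min, tested at 1 uM; on this read-out lower numbers stand for less inhibition and higher numbers for more inhibition at the one concentration tested (going by the name of the read-out). Compound 1 `COc1c(C(=O)CCC2CCN(CC3CCCCC3)CC2)cc(Cl)c2[nH]ccc12` gives 100%, compound 2 `COc1c(C(=O)CCC2CCN(Cc3ccccc3)CC2)cc(Cl)c2[nH]ccc12` gives 96%, and compound 3 `O=C(CCC1CCN(Cc2ccccc2)CC1)c1ccc2[nH]ccc2c1` gives 90%. Compound 2 and compound 1 differ in a single place, (cyclohexyl in place of phenyl on a saturated chain carbon bound to an amine nitrogen in a ring), and that change made a step of a number 4 percentage points higher from compound 2 to compound 1 (within the scatter). Compound 3 stands on a different core; the difference between the two cores is not broken down here, and the values of compound 2 and compound 3 simply show both well inhibited at this concentration.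

Compound 4 `O=C(CCC1CCN(CC2CCCCC2)CC1)c1ccc2[nH]ccc2c1` has not yet been measured. It differs from compound 3 by cyclohexyl in place of phenyl on a saturated chain carbon bound to an amine nitrogen in a ring, the same change that was made from compound 2 to compound 1, so among these compounds the change occurs twice. Since the earlier step of a number 4 percentage points higher from compound 2 to compound 1 (within the scatter) stayed within the scatter, a step of similar size is expected here as well, namely a number 3 percentage points higher from compound 3 to compound 4 (within the scatter). Compound 4 is therefore estimated at 93% in this assay, between 82% and 100%.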

Compound 4, a percentage reported as inhibition, at one concentration (the size of the read-out at that concentration, not a potency): 100%
Compound 4: the middle estimate sits 7 percentage points below what was measured, within the range that was stated.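

In this assay the change from phenyl to cyclohexyl can now be read on two cores, and the new step, a number 10 percentage points higher from compound 3 to compound 4 (within the scatter), lies within the scatter, as the earlier one does. Set side by side, the two steps do not differ by more than repeated measurement would allow: the same change on two cores in this assay, a number 4 percentage points higher (within the scatter) from compound 2 to compound 1 and a number 10 percentage points higher (within the scatter) from compound 3 to compound 4, 6 percentage points apart, within the scatter of two such steps This shows that the change carried from one core to the other with no separable difference in outcome, but it does not show that the change raises inhibition on either core, and a read-out at one concentration is not a potency.

The compounds shown leave open how other groups would fare on a saturated chain carbon bound to an amine nitrogen in a ring, for example cyclopentyl or a longer chain ending in cyclohexyl. They also leave open whether the same change would read alike on a further core, such as one carrying a carboxylic acid or an amine.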